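Ring-nitrogen substituent change in a peptide-linked series

The compounds below may be only part of what the source reports. "The series", "measured", "known", "first", "only" and "open" are said of these compounds alone.

Measured so far:
compound 1 `CCCC[C@H](NC(=O)[C@H](CCCCN)NC(=O)[C@H](CCCNC(=N)N)NC(=O)c1ccc(/C=C2\SC(=O)N(C3CCCCC3)C2=O)cc1)C(N)=O`: 1.69 10^-6 cm/s
compound 2 `CCCC[C@@H](NC(=O)[C@@H](CCCCN)NC(=O)[C@@H](CCCNC(=N)N)NC(=O)c1ccc(/C=C2\SC(=O)N(Cc3ccccc3)C2=O)cc1)C(N)=O`: 0.29 10^-6 cm/s

In an ADME assay for permeability, using PAMPA (on this read-out lower numbers stand for lower permeability and higher numbers for higher permeability), compound 1 gives 1.69 10^-6 cm/s, the higher of the two numbers; compound 2 gives 0.29 10^-6 cm/s, and the gap between the two lies beyond the scatter. Compound 3 `CCCC[C@H](NC(=O)[C@H](CCCCN)NC(=O)[C@H](CCCNC(=N)N)NC(=O)c1ccc(/C=C2\SC(=O)N(CCOC(C)=O)C2=O)cc1)C(N)=O` has not been measured. It differs from compound 1 by 2-acetoxyethyl in place of cyclohexyl on an amide-type nitrogen in a ring. For the measured compounds named here, no step between measured compounds covers this change, so the expectation rests only on compound 1 and its value of 1.69 10^-6 cm/s. A downward step beyond the scatter is expected, a 3.4-fold lower number from compound 1 to compound 3 (0.53 log units; beyond the scatter). Compound 3 is therefore estimated at 0.5 10^-6 cm/s, with a range from 0.15 10^-6 cm/s to 1.5 10^-6 cm/s.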

Compound 3, apparent permeability: "impermeable" (no number reported)
The entry for compound 3 holds no number; there is nothing to compare the estimate with.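

In this assay, for the compounds shown here, compound 3 is entered as "impermeable" with no number, so no step from compound 1 can be read. No evidence on a cause is at hand. The compounds shown leave open how large the change from cyclohexyl to 2-acetoxyethyl is on this read-out.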